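Trading Bromo for Chloro on a Potent Compound

The source may report more compounds than this note shows. Statements on the series, on what has been measured and on what is new or still open speak of the compounds shown alone.

In a functional assay on HCT-116 cells (Homo sapiens) for antiproliferative activity, read by MTT assay, with a stated time of 72 h (on this read-out higher numbers stand for weaker inhibition and lower numbers for stronger inhibition), compound 1 `NC1=NC2(CCSCC2)N(OCCCOc2ccc(Br)cc2)C(N)=N1` gives 20 nM and compound 2 `NC1=NC2(CCSCC2)N(OCCCOc2ccccc2Br)C(N)=N1` gives 1 nM which is the lower of the two numbers. Compound 3 `NC1=NC2(CCSCC2)N(OCCCOc2ccccc2Cl)C(N)=N1` is still unmeasured, and its structure differs from that of compound 2 in one place: chloro in place of bromo on an aromatic carbon with chloro in place of bromo on an aromatic carbon. Among the measured compounds shown here, the only measured step of a 20-fold lower number from compound 1 to compound 2 (1.30 log units; beyond the scatter) came with 2-bromophenyl in place of 4-bromophenyl and was large, beyond the scatter. That step relocated the bromo and did not replace it, so no measurement here compares chloro with bromo. The 2-chlorophenyl of compound 3 keeps the halogen where compound 2 has it, so only a small change is expected. The expected step of a 2.0-fold higher number from compound 2 to compound 3 (0.30 log units; within the scatter) is modest and points towards a slightly higher number. For compound 3 the estimated value is 2 nM with an expected range from 0.7 nM to 6 nM in this assay once it is measured.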

Compound 3, half-maximal inhibitory concentration: 1 nM
Beside the measured number, compound 3's estimate is 2.0-fold (0.30 log units) above it, and the stated range covers the measured number.
By their numbers in this assay, from the lowest: compounds 2 and 3 (each within the scatter of the next); then compound 1.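

In this assay, among the compounds shown here, chloro in place of bromo on this aromatic carbon gives no change at the digits printed from compound 2 to compound 3 (within the scatter), the only direct comparison of these two halogens at this position. The step of a 20-fold lower number from compound 1 to compound 3 (1.30 log units; beyond the scatter) is as large as the one seen with 2-bromophenyl, so the low number is not tied to bromine: among these compounds, 2-chlorophenyl and 2-bromophenyl read alike. No measured information here accounts for this match between the two halogens.

On these data alone, it remains open whether fluoro, methyl, methoxy or an amine on the same carbon would keep the number this low. As far as these compounds go, it is also open whether chloro in the place held by the bromo of compound 1 would give a number close to that of compound 1.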